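Hydroxyethyl on the five-membered ring nitrogen of compound 3

The compounds below may be only part of what the source reports. "The series", "measured", "known", "first", "only" and "open" are said of these compounds alone.

Compound 3 `CCCn1c(=O)n(C)c(=O)c2[nH]cnc21` gives the lowest number of the three measured compounds in a functional assay (trachea) with Cavia porcellus as the target (a lower number here means that less compound is needed, a higher number that more compound is needed for the effect), with 1600 nM. Compound 2 `CCCn1c(=O)n(CCC(C)=O)c(=O)c2[nH]cnc21` gives 3500 nM in this assay, and compound 1 `CCCn1c(=O)n(CCCN(C)C)c(=O)c2[nH]cnc21` gives 20500 nM. Both measured steps into compound 3 lower the number: a 13-fold lower number from compound 1 to compound 3 (1.11 log units; beyond the scatter) and a 2.2-fold lower number from compound 2 to compound 3 (0.34 log units; beyond the scatter). The remaining step, a 5.9-fold lower number from compound 1 to compound 2 (0.77 log units; beyond the scatter), also lowers it.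

Compound 4 `CCCn1c(=O)n(C)c(=O)c2c1ncn2CCO` differs from compound 3 by 2-hydroxyethyl in place of hydrogen on an aromatic nitrogen. Within the data shown here, every measured step concerns a saturated chain carbon bound to the other aromatic nitrogen; none touches the aromatic nitrogen of the five-membered ring, so no step bears directly on this change. Indirectly, each chain present in compound 1 and compound 2 came with a higher number than the hydrogen of compound 3, and the new 2-hydroxyethyl group, with its hydrogen-bond donor and acceptor, is a chain of comparable length. A modest rise in the number is therefore expected, with wide uncertainty given the new place.

For compound 4 the number in this assay is estimated at 4000 nM, within a range of 1200 nM to 14000 nM, which is an expected step of a 2.5-fold higher number from compound 3 to compound 4 (0.40 log units; beyond the scatter).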

Compound 4, half-maximal effective concentration: 31800 nM
For compound 4 the middle estimate is 8.0-fold (0.90 log units) below the measured one; the measured number lies above the stated range.
By their numbers in this assay, from the lowest: compound 3; then compound 2; then compounds 1 and 4 (each within the scatter of the next).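

In this assay, among these compounds, the first change on the aromatic nitrogen of the five-membered aromatic ring gives a 20-fold higher number from compound 3 to compound 4 (1.30 log units; beyond the scatter), so this nitrogen does not accept 2-hydroxyethyl without a large rise in the number. A chain in place of hydrogen now goes with a higher number on both aromatic nitrogens, and no compound shown goes against this, but the size varies: the step with 2-hydroxyethyl is large, like the one with 2-(dimethylamino)ethyl on the other nitrogen (a 13-fold lower number from compound 1 to compound 3 (1.11 log units; beyond the scatter)), whereas the one with 2-oxopropyl is modest (a 2.2-fold lower number from compound 2 to compound 3 (0.34 log units; beyond the scatter)). No measurement in the series gives a reason for the size of the new step.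

Among the compounds shown here, with only one group on this nitrogen, the share of the step belonging to the hydroxyl and the share belonging to the two-carbon chain carrying it cannot be told apart. On these data alone, whether methyl, ethyl, 2-methoxyethyl, an amine such as 2-(dimethylamino)ethyl or a carboxylic acid on this nitrogen would raise the number as far as 2-hydroxyethyl does remains open.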